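From Fluoro to Amino: What to Expect for Compound 4

A few compounds are considered here, and "the series" means these few. Any claim that something is new, unique, unknown or untested is made for them only; others in the source may bear on it.

Of the compounds shown here, three sharing one core have been tested in a functional assay on KYSE-410 cells (Homo sapiens) for antiproliferative activity, read by MTT assay, with a stated time of 72 h; on this read-out lower numbers stand for stronger inhibition and higher numbers for weaker inhibition. Compound 1 `O=C(Nc1cccc(Cl)c1)c1cc(=O)[nH]c2cc(Br)ccc12` reaches only a limit of the assay, giving > 20000 nM. Compound 2 `O=C(Nc1cc(F)cc(F)c1)c1cc(=O)[nH]c2cc(F)ccc12` likewise stops at a limit, with > 20000 nM. Among the measured compounds shown here, compound 3 `O=C(Nc1cccc(F)c1)c1cc(=O)[nH]c2cc(-c3ccc(F)cc3)ccc12` is the only one with a real number: in this assay compound 3 gives 10300 nM, which sets it apart from the limit of > 20000 nM in this assay, at which 2 of the 3 values shown sit. Compound 4 `Nc1ccc(-c2ccc3c(C(=O)Nc4cccc(F)c4)cc(=O)[nH]c3c2)cc1` differs from compound 3 in a single place: amino in place of fluoro on an aromatic carbon. For the measured compounds named here, no step between two measured compounds is known, so any expectation rests on compound 3 alone. A modest gain is expected, with the step from compound 3 to compound 4 estimated at a 2.1-fold lower number from compound 3 to compound 4 (0.31 log units; beyond the scatter). Compound 4 is expected to give about 5000 nM in this assay, within a range of 1500 nM to 20000 nM.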

Compound 4, half-maximal inhibitory concentration: > 20000 nM
Compound 4: a limit, no number; the forecaster's own chance of this, stated with the estimate: 25%; middle value at least 4.0-fold (0.60 log units) away from the limit.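

Among the compounds shown here, the change from 4-fluorophenyl to 4-aminophenyl gives the only readable step at this position: an at least 1.9-fold higher number from compound 3 to compound 4 (0.28 log units; that floor lies within the scatter). Compound 4 gives a limit and not a number, so the step has only a floor, and that floor alone does not establish a real loss of activity. Compound 4 now shares the limit reached by compounds 1 and 2: the limit of > 20000 nM in this assay, at which 3 of the 4 values shown sit.

The compounds shown leave open how a hydroxyl or a methoxy group on this same carbon would compare with the fluoro of compound 3. Going by these compounds, how far the true value of compound 4 lies past its limit also stays open.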